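Nitrophenyl swap on a bis-piperazine compound

The source may hold more compounds than are shown below. What is called first, only, known or untested is meant among the compounds shown, and "the series" means these compounds.

Compound 1 `COc1ccccc1N1CCN(CCN2CCN(c3ccccc3OC)CC2)CC1` gives 40000 nM
Compound 2 `Fc1ccc(N2CCN(CCN3CCN(c4ccc(F)cc4)CC3)CC2)cc1` gives 71200 nM
Compound 3 `O=[N+]([O-])c1ccc(N2CCN(CCCN3CCN(c4ccc([N+](=O)[O-])cc4)CC3)CC2)cc1` gives 11800 nM

All three numbers come from a functional assay on LNCaP cells (Homo sapiens) for cytotoxicity, read by MTT assay, with a stated time of 24 h; a lower number here means that less compound is needed, a higher number that more compound is needed for the effect. Compound 1 lies within the usual scatter of compound 2, so these two cannot be told apart. Compound 3 stands at a lower number than compound 1, and that gap goes beyond the scatter.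

Compound 4 `COc1ccccc1N1CCN(CCN2CCN(c3ccc([N+](=O)[O-])cc3)CC2)CC1` keeps one half of compound 1 and changes the other. The change is 4-nitrophenyl in place of 2-methoxyphenyl on an amine nitrogen in a ring.

For the measured compounds named here, no measured pair shows this change alone. Going by the values given here, the only hint is compound 3, which carries 4-nitrophenyl and gives 11800 nM, but its structure differs from compound 1 in other ways too. A small move toward a lower number in this assay is therefore expected, perhaps not beyond the scatter. The estimated step is a 1.7-fold lower number from compound 1 to compound 4 (0.24 log units; within the scatter). For compound 4 the expected value is 23000 nM, with an estimated range from 9000 nM to 55000 nM.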

Compound 4, half-maximal effective concentration: 46500 nM
For compound 4 the middle estimate is 2.0-fold (0.31 log units) below the measured one; measured number inside the range.
By their numbers in this assay, from the lowest: compound 3; then compounds 1, 4 and 2 (each within the scatter of the next).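

For the compounds shown here, this is the first direct reading of this position, since compound 1 and compound 4 differ in one place only. In this assay, placing 4-nitrophenyl instead of 2-methoxyphenyl on the amine nitrogen in the ring gives a 1.2-fold higher number from compound 1 to compound 4 (0.07 log units; within the scatter), so the two compounds cannot be told apart, and this one swap leaves the result unchanged within the usual scatter. No independent measurement is available here to explain this outcome.

On these data alone, compound 3 differs from compound 4 in more than one place, so the source of its separate value stays open, whether that is its second 4-nitrophenyl group or its longer chain. It is also unknown whether a phenyl ring carrying an amine or a carboxylic acid at this position would move the number beyond the scatter.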